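This account rests on a few compounds, and the source may have more. Where it says the series, first, only, none or still open, it means among the compounds named here.

Measured so far:
- compound 1 `CS(=O)(=O)Cc1cc([C@]23CCOC[C@H]2C3)nc(-c2cccc(O)c2)n1`: 75 ug/mL
- compound 2 `Oc1cccc(-c2nccc(C34CCOCC3C4)n2)c1`: 102 ug/mL
- compound 3 `Oc1cccc(-c2nccc([C@]34CCOC[C@H]3C4)n2)c1`: 141 ug/mL

In a physicochemical assay for solubility, in phosphate buffer, measured as kinetic solubility, with a stated time of 1 h, at pH 7.4 (a higher number here means a more soluble compound, a lower number a less soluble compound), compound 1 gives 75 ug/mL, the lowest of the three numbers shown. Compound 2 gives 102 ug/mL and compound 3 gives 141 ug/mL; each of these stands within the scatter of compound 1, so the three are not separated by this assay.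

Compound 4 `CS(=O)(=O)Cc1cc([C@@]23CCOC[C@@H]2C3)nc(-c2cccc(O)c2)n1` is the next compound. Relative to compound 1 the change is the two compounds have the same atoms and bonds and differ only in configuration as drawn: 2 of 2 stereo elements differ (all stereocentres are inverted: mirror images); a stereocentre at a saturated ring carbon is drawn R in compound 1 and S in compound 4; a stereocentre at a saturated ring carbon is drawn S in compound 1 and R in compound 4.

Going by the values given here, only one measured step touches configuration at these ring carbons: a 1.4-fold higher number from compound 2 to compound 3 (0.14 log units; within the scatter). That pair is an imperfect guide to a mirror-image comparison because of the fact that one of compounds 2 and 3 is drawn with a defined configuration and the other without, at the place where they differ, but whatever it shows, it stays within the scatter. The other measured step, a 1.9-fold higher number from compound 1 to compound 3 (0.27 log units; within the scatter), concerns removal of the (methylsulfonyl)methyl group and does not bear on the present change.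

For compound 4 the expectation is therefore no step beyond the scatter in this assay relative to compound 1, in either direction, which is what no change at the digits printed from compound 1 to compound 4 (within the scatter) is meant to express. The estimate for compound 4 in this assay is 75 ug/mL, with a range from 40 ug/mL to 140 ug/mL.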

Compound 4, solubility: 145 ug/mL
The estimate for compound 4 lay 1.9-fold (0.29 log units) below the measured number, and the stated range ends below it.
By their numbers in this assay, from the lowest: compounds 1, 2, 3 and 4 (each within the scatter of the next).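

In this assay the mirror-image pair gives a 1.9-fold higher number from compound 1 to compound 4 (0.29 log units; within the scatter), so with the (methylsulfonyl)methyl group in place, the two configurations at the saturated ring carbons are not separated by this measurement. The earlier configuration step, a 1.4-fold higher number from compound 2 to compound 3 (0.14 log units; within the scatter), could not settle this point, as it compares a defined drawing with an undefined one: the fact that one of compounds 2 and 3 is drawn with a defined configuration and the other without, at the place where they differ. The new step is the cleaner reading of configuration alone, with no other structural change to account for, and it still does not go beyond the scatter: the fact that compounds 1 and 4 differ only in the configuration as drawn.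

Open, as far as these compounds go, is whether an amine or a carboxylic acid in place of the (methylsulfonyl)methyl group would give a step beyond the scatter in this assay, and whether the two configurations would remain unseparated with such a group present. Also open, from the compounds shown here alone, is how compound 1 and compound 4 compare in any read-out other than this assay, since configuration could yet separate the two mirror images elsewhere.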